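Swapping thiophen-2-yl for phenyl on a weak compound

This account rests on a few compounds, and the source may have more. Where it says the series, first, only, none or still open, it means among the compounds named here.

Values in a functional assay on HCT-116 cells (Homo sapiens), read by MTT assay, with a stated time of 72 h (on this read-out lower numbers stand for stronger inhibition and higher numbers for weaker inhibition), for the measured compounds

- Compound 1 (`O=c1[nH]cnc2c1c(-c1ccccc1)cn2[C@@H]1O[C@H](CO)[C@@H](O)[C@H]1O`) gives > 100000 nM as a limit
- Compound 2 (`Nc1nc2c(c(-c3ccoc3)cn2[C@@H]2O[C@H](CO)[C@@H](O)[C@H]2O)c(=O)[nH]1`) gives 14200 nM as a number
- Compound 3 (`Nc1nc2c(c(-c3cccs3)cn2[C@@H]2O[C@H](CO)[C@@H](O)[C@H]2O)c(=O)[nH]1`) gives > 20000 nM as a limit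

Compound 3 stands at the limit of > 20000 nM in this assay, at which 1 of the 3 values shown sits, and this is a limit, not a number. Compound 4 (`Nc1nc2c(c(-c3ccccc3)cn2[C@@H]2O[C@H](CO)[C@@H](O)[C@H]2O)c(=O)[nH]1`) differs from it by one change: phenyl in place of thiophen-2-yl on an aromatic carbon on the same aromatic carbon. Among the compounds with values here, the one measured step that bears on this also swaps one aromatic ring for another, an at least 1.4-fold higher number from compound 2 to compound 3 (0.14 log units; that floor lies within the scatter) and gives only a floor. Compound 1 also carries phenyl, and its value > 100000 nM is a limit too. Nothing here points to a large gain, so the expected change is none beyond the scatter, a step that the limit leaves unreadable from compound 3 to compound 4 as estimated. For compound 4 the estimate is 25000 nM with an expected range from 9000 nM to 70000 nM in this assay and weak inhibition is expected.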

Compound 4, half-maximal inhibitory concentration: > 20000 nM
Compound 4 was reported as a limit; the forecaster's own chance of this, stated with the estimate: 65%; the middle value is on the limit's open side.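

In this assay, compound 4 is reported only as a limit, so phenyl at this position, like thiophen-2-yl in compound 3, yields no measured number: the limit of > 20000 nM in this assay, at which 2 of the 4 values shown sit.

The steps to compound 4 from compound 3 and from compound 1 cannot be read. Within the data shown here, the one readable step is an at least 1.4-fold higher number from compound 2 to compound 4 (0.14 log units; that floor lies within the scatter), and furan-3-yl in compound 2 remains the only group here with a measured number.

As far as these compounds go, how far compound 3 and compound 4 lie past their limits stays open. So does the effect of an amine or a carboxylic acid on this aromatic carbon.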